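Chlorine for fluorine, then a methyl back on the urea

The source may report more compounds than this note shows. Statements on the series, on what has been measured and on what is new or still open speak of the compounds shown alone.

In a functional assay on EC9706 cells (Homo sapiens) for cytotoxicity, read by MTT assay, with a stated time of 72 h (on this read-out lower numbers stand for stronger inhibition and higher numbers for weaker inhibition), the two compounds measured so far gave:
- compound 1 `CC(C)NC(=O)N1CCN(C(=S)SCc2cn(Cc3ccc(F)cc3)nn2)CC1`: 12200 nM
- compound 2 `CCNC(=O)N1CCN(C(=S)SCc2cn(Cc3ccc(Cl)cc3)nn2)CC1`: > 128000 nM

Compound 2 stands apart from compound 1 in that its result is a limit of the assay rather than a number; of the two values shown, it is the one that sits at the limit of > 128000 nM in this assay, at which 1 of the 2 values shown sits. Compound 1 gives a measured number in this assay.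

Compound 3 `CC(C)NC(=O)N1CCN(C(=S)SCc2cn(Cc3ccc(Cl)cc3)nn2)CC1` is the unmeasured partner of compound 2. Within the data shown here, the only change is methyl in place of hydrogen on a saturated chain carbon bound to an amide-type nitrogen and a saturated chain carbon, so the ethylcarbamoyl group of compound 2 becomes the isopropylcarbamoyl group that compound 1 also carries. Among the measured compounds shown here, no step between measured compounds isolates this change, so its size can only be guessed. Compound 2 gave only a limit in this assay. Compound 1, which carries the isopropylcarbamoyl group, gave 12200 nM. The expectation is that compound 3 falls somewhere between these two results, with a real chance that it again reaches only the limit. The estimated step from compound 2 to compound 3 is therefore an at least 3.6-fold lower number from compound 2 to compound 3 (0.56 log units; beyond the scatter), toward stronger inhibition. Compound 3 is estimated at 35000 nM, within 9000 nM to 150000 nM.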

Compound 3, half-maximal inhibitory concentration: 25600 nM
For compound 3 the middle estimate is 1.4-fold (0.14 log units) above the measured one; measured number inside the range.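

In this assay, the change from ethylcarbamoyl to isopropylcarbamoyl now has a size with chloro held fixed, and a single added methyl carries a compound from a limit to a measured number: an at least 5.0-fold lower number from compound 2 to compound 3 (0.69 log units; beyond the scatter). That size is only a bound, as compound 2 has a limit of the assay and not a number: the limit of > 128000 nM in this assay, at which 1 of the 3 values shown sits.

Chloro in place of fluoro on an aromatic carbon, with the isopropylcarbamoyl group held fixed, gives a 2.1-fold higher number from compound 1 to compound 3 (0.32 log units; beyond the scatter), a modest step that lies just beyond the usual scatter, so a chloro compound can still give a measured number when it carries the isopropylcarbamoyl group.

The compounds shown stop at ethyl and isopropyl, so it remains open whether a longer chain such as butyl, a bulkier group such as tert-butyl or a ring such as cyclopropyl would lower the number further or raise it again. On the aromatic ring, only fluoro and chloro appear, which leaves bromo or methoxy in the same place as open questions.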